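The source may report more compounds than this note shows. Statements on the series, on what has been measured and on what is new or still open speak of the compounds shown alone.

Measured compounds:
compound 1 `C=C1CC[C@@H]2[C@](C)(CO)[C@H](O)CC[C@@]2(C)[C@@H]1CCC1=CCOC1=O` gives "not active" (no number reported) in a functional assay on MCF7 cells (Homo sapiens) for cytotoxicity, read by MTT assay, with a stated time of 48 h; a higher number here means a weaker inhibitor, a lower number a stronger inhibitor.
compound 2 `C=C1CC[C@@H]2[C@](C)(COC(=O)CC)[C@H](OC(=O)CC)CC[C@@]2(C)[C@@H]1CCc1ccoc1` reaches only the limit > 100000 nM in this assay.
compound 3 `C=C1CC[C@@H]2[C@](C)(COC(=O)C(Cl)Cl)[C@H](OC(=O)C(Cl)Cl)CC[C@@]2(C)[C@@H]1CCc1ccoc1` gives 22900 nM in this assay.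

Among the measured compounds shown here, compound 1 stands without a single number in this assay: its result is a statement of no activity, and the only other value near it is the limit at which compound 2 sits (the limit of > 100000 nM in this assay, at which 1 of the 3 values shown sits). Compound 3 alone gives a number, and it is a weak one. For the measured compounds named here, none of the three measured compounds differs from another in one place, so no measured step is available to gauge the change that leads to compound 4 `C=C1CC[C@@H]2[C@](C)(CO)[C@H](O)CC[C@@]2(C)[C@@H]1CC(O)c1ccoc1`. Compound 4 differs from compound 1 in this way: a group of 7 heavy atoms (5 carbon, 2 oxygen; one five-membered aromatic ring with 1 hetero atom) in place of a group of 7 heavy atoms (5 carbon, 2 oxygen; one five-membered non-aromatic ring with 1 hetero atom), on a saturated chain carbon bound to a saturated ring carbon. With compound 1 showing no activity and compound 2 at a limit of this assay, the shared core carrying free hydroxyls has given nothing better than weak inhibition so far, and compound 4 is expected to stay in that region, with no step beyond the scatter foreseen in either direction. Compound 4 is therefore estimated at 70000 nM in this assay, within a range from 15000 nM to 200000 nM, and it may well be reported only as a limit.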

Compound 4, half-maximal inhibitory concentration: > 100000 nM
Compound 4 gave a limit, no number (the forecaster's own chance of this, stated with the estimate: 50%); middle value at least 1.4-fold (0.15 log units) from the limit.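

Compound 4 gives only the limit > 100000 nM in this assay. Among the compounds shown here, compound 1 gives "not active" (no number reported) in this assay and so no step to compound 4 can be read. The compounds shown leave open whether exchanging the five-membered non-aromatic ring group for (furan-3-yl)(hydroxy)methyl on this shared core changes activity at all in this assay.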